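A few compounds are considered here, and "the series" means these few. Any claim that something is new, unique, unknown or untested is made for them only; others in the source may bear on it.

Measured so far in a functional assay on KB cells (Homo sapiens) for inhibition, read by MTT assay, with a stated time of 24 h, tested at 0.1 ug/mL; on this read-out lower numbers stand for less inhibition of growth and higher numbers for more inhibition of growth at the one concentration tested
compound 1 `O=C(O)CCCCC(CCSC(=O)c1ccccc1)SC(=O)c1ccccc1` gives "not active" (no number reported)
compound 2 `O=C(CCCCC(CCSC(=O)c1ccccc1)SC(=O)c1ccccc1)Nc1ccccc1` gives 1.52%

In this assay, within the data shown here, compound 2 gives 1.52% as the only number available, while compound 1 is reported as "not active" (no number reported) and has no number. Compound 3 `O=C(CCCCC(CCSC(=O)c1ccccc1)SC(=O)c1ccccc1)Nc1ccccc1Cl` is compound 2 with chloro in place of hydrogen on an aromatic carbon, so that phenylcarbamoyl becomes (2-chlorophenyl)carbamoyl, and the count of this difference reads chloro in place of hydrogen on an aromatic carbon for the pair. Among the measured compounds shown here, no two measured compounds differ in one place, so no measured step is available as a guide. The expected step of a number 2.5 percentage points higher from compound 2 to compound 3 (within the scatter) is therefore small, perhaps slightly upward, and is not expected to go beyond the usual scatter. In this assay compound 3 is estimated at 4% with an expected range from 0% to 14% at the one concentration tested.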

Compound 3, percent growth inhibition at one concentration: 3.62%
Compound 3: middle estimate off by 0.4 percentage points, on the high side; low and high end bracket the measured number.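

In this assay, chloro in place of hydrogen on an aromatic carbon, ortho to a large group, gives a number 2.1 percentage points higher from compound 2 to compound 3 (within the scatter). Among these compounds, this is the first step that can be read, and it shows that going from phenylcarbamoyl to (2-chlorophenyl)carbamoyl does not separate the two compounds at the one concentration tested, with both values staying close to the bottom of the scale. Nothing available here bears on how this result arises.

The compounds shown leave open whether a methoxy group, a nitro group or a dimethylamino group on this aromatic ring would give a step beyond the scatter. They also leave open whether a second chloro on the same ring would move the read-out any further.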